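The source may report more compounds than this note shows. Statements on the series, on what has been measured and on what is new or still open speak of the compounds shown alone.

Compound 1 `CCNc1nc(N)c2nc(O)n(Cc3ccccc3)c2n1` is tested in a functional assay (spleen, spleen) for activation, with Mus musculus as the target (on this read-out lower numbers stand for an effect already at smaller amounts and higher numbers for an effect only at larger amounts of compound), where compound 1 gives 1 uM. Among the two compounds that give a number in this assay, compound 1 stands highest. Compound 2 `CCCCOc1nc(N)c2[nH]c(=O)n(Cc3ccccc3)c2n1` gives 0.001 uM in this assay, a far lower number, and the gap between the two lies well beyond the usual scatter. Compound 3 `Nc1ncnc2c1nc(I)n2Cc1ccccc1` reaches only the limit of the assay, > 10 uM, and no number is known for compound 3; this is the case described by the limit of > 10 uM in this assay, at which 1 of the 3 values shown sits. Compound 4 `CCCSc1nc(N)c2nc(O)n(Cc3ccccc3)c2n1` has not yet been measured. It differs from compound 1 in one place: propylsulfanyl in place of ethylamino on an aromatic carbon. Within the data shown here, no measured pair shows this very change, and the expectation rests on the wide spread between compound 1 and compound 2. A step of a 100-fold lower number from compound 1 to compound 4 (2.00 log units; beyond the scatter) toward a lower number is expected, beyond the scatter. In this assay compound 4 is expected to give about 0.01 uM, with the likely range running from 0.001 uM to 0.3 uM.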

Compound 4, minimum effective concentration: 0.01 uM
Beside the measured number, compound 4's estimate shows no gap at the digits printed, and the stated range covers the measured number.
By their numbers in this assay, from the lowest: compound 2; then compound 4; then compound 1. At a limit, above all of these: compound 3.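

Among these compounds, the aromatic carbon between two ring nitrogen atoms turns out to respond strongly to a single change: swapping ethylamino for propylsulfanyl gives a 100-fold lower number from compound 1 to compound 4 (2.00 log units; beyond the scatter) in this assay, the first pair here that differs in only one place. Ethylamino carries one hydrogen-bond donor and propylsulfanyl none, so a donor on this carbon is not needed for a low number in this assay. Nothing measured here explains the size of this step.

The swap alters the atom that links the chain to the ring and lengthens the chain at the same time, so the two effects cannot be separated. Values for propylamino and ethylsulfanyl at this carbon would tell them apart, and how a carboxylic acid would behave there also remains open.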